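Ring-to-chain swap on the core nitrogen of compound 1

The compounds below may be only part of what the source reports. "The series", "measured", "known", "first", "only" and "open" are said of these compounds alone.

Going by the values given here, compound 1 `O=c1c(S(=O)(=O)c2ccc(F)cc2F)cc2cnc(Nc3ccc4[nH]ccc4c3)nc2n1C1CC1` in a functional assay on K562 cells (Homo sapiens) for inhibition, read by trypan blue exclusion, with a stated time of 72 h (a higher number here means a weaker inhibitor, a lower number a stronger inhibitor), gives 500 nM, the lowest of the three numbers measured so far. Compound 3 `Cn1c(=O)c(S(=O)(=O)c2ccc(Cl)cc2Cl)cc2cnc(Nc3ccc4[nH]ccc4c3)nc21` in this assay gives 1000 nM, which lies within the scatter of compound 1. Compound 2 `Cc1ccc(S(=O)(=O)c2cc3cnc(Nc4cnc5[nH]ccc5c4)nc3n(C)c2=O)cc1` in this assay gives 15000 nM, beyond the scatter from compound 1. Among the compounds with values here, no pair of measured compounds differs in one place, so no single step is known to anchor an expectation.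

Compound 4 `CCn1c(=O)c(S(=O)(=O)c2ccc(F)cc2F)cc2cnc(Nc3ccc4[nH]ccc4c3)nc21` differs from compound 1 by ethyl in place of cyclopropyl on an aromatic nitrogen. The change is small in size and leaves the rest of the molecule untouched. The expected step of a 1.4-fold higher number from compound 1 to compound 4 (0.15 log units; within the scatter) is none beyond the scatter, with a slight weakening as the more likely direction. Compound 4 is therefore estimated at 700 nM, in the range 300 nM to 1800 nM.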

Compound 4, half-maximal inhibitory concentration: 750 nM
Estimate against measurement, compound 4: 1.1-fold (0.03 log units) below, within the range that was stated.
By their numbers in this assay, from the lowest: compounds 1, 4 and 3 (each within the scatter of the next); then compound 2.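

Going by these compounds alone, the first single-place step at this aromatic nitrogen is a 1.5-fold higher number from compound 1 to compound 4 (0.18 log units; within the scatter) in this assay and replaces cyclopropyl with ethyl. At this position, the three-membered ring can therefore give way to an open chain with no change beyond the scatter. No measurement shown offers an explanation for this result.

Still open, going by these compounds, is whether a longer chain would hold up in the same way at this nitrogen. The same question applies to a chain ending in an amine or a carboxylic acid.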